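The source may hold more compounds than are shown below. What is called first, only, known or untested is meant among the compounds shown, and "the series" means these compounds.

Measured so far:
compound 1, `CCC/N=C(/NC#N)NCCCCCn1nc(-c2ccccc2)ccc1=O`: > 100 mg/kg
compound 2, `CC/N=C(/NC#N)NCCCn1nc(C)ccc1=O`: > 100 mg/kg

In a functional assay on the whole organism (stomach) with Rattus norvegicus as the target (a lower number here means that less compound is needed, a higher number that more compound is needed for the effect), compound 1 gives > 100 mg/kg, which is a limit of the assay and not a measured number. In this assay compound 2 gives > 100 mg/kg, again a limit rather than a number. Where compound 1 stands is therefore known only as the limit of > 100 mg/kg in this assay, at which 2 of the 2 values shown sit, the same place as the one other compound measured in this assay.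

Compound 3, `C/N=C(\S)NCCCCCn1nc(-c2ccccc2)ccc1=O`, has not been tested yet. It differs from compound 1 in one place: a group of 4 heavy atoms (2 carbon, 1 nitrogen, 1 sulfur; no ring) in place of a group of 8 heavy atoms (5 carbon, 3 nitrogen; no ring), on an amine nitrogen. Within the data shown here, no step between two measured compounds is known, so nothing shows how a change of this kind has moved the dose before. With only two limits to go on, the step from compound 1 to compound 3 is expected to stay within the scatter, a number no higher from compound 1 to compound 3 (the limit leaves the size open), with a fair chance that the assay reports a limit once more. In this assay compound 3 is estimated at 100 mg/kg, in the range 30 mg/kg to 300 mg/kg.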

Compound 3, dose for half-maximal effect: 35.3 mg/kg
For compound 3 the middle estimate is 2.8-fold (0.45 log units) above the measured one; the measured number falls inside the stated range.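

In this assay, the amine nitrogen attached to the saturated chain carbon now proves to be a place where the choice of group can change the dose, something two compounds sitting at the same limit could not reveal. Among these compounds, putting the group of 4 heavy atoms (2 carbon, 1 nitrogen, 1 sulfur; no ring) in place of the group of 8 heavy atoms (5 carbon, 3 nitrogen; no ring) gives an at least 2.8-fold lower number from compound 1 to compound 3 (0.45 log units; beyond the scatter), and so brings the first actual number. Compound 1 gives > 100 mg/kg, which is a limit of the assay and not a number, so the true size of the step remains unknown, and the limit is shared by most of what is shown: the limit of > 100 mg/kg in this assay, at which 2 of the 3 values shown sit.

The change replaces the whole group at once, so the compounds shown cannot separate the arrival of the sulfur from the loss of the nitrile or from the smaller size of the group. From the compounds shown here alone, it also remains open whether other groups on this nitrogen, such as an amide or a carboxylic acid, would lower the dose further, and whether the same exchange would work with a shorter chain.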